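Swapping the aryl group on an imidazole core

The source may report more compounds than this note shows. Statements on the series, on what has been measured and on what is new or still open speak of the compounds shown alone.

Compound 1 `COc1ccc(-c2nc(-c3ccccc3)c(-c3ccc4c(c3)NC(=O)CO4)[nH]2)cc1` gives 96%
Compound 2 `O=C1COc2ccc(-c3nn(-c4cc(Cl)cc(Cl)c4)cc3-c3ccccc3)cc2N1` gives 90.3%

In a functional assay on DLD-1 cells (Homo sapiens) for cytotoxicity, read by colorimetric assay and MTT assay, with a stated time of 3 days, tested at 1 uM (on this read-out lower numbers stand for a stronger effect and higher numbers for a weaker effect at the one concentration tested), compound 1 gives 96%, the higher of the two numbers, while compound 2 gives 90.3%, a gap that lies within the scatter. Compound 3 `O=C1COc2ccc(-c3[nH]c(-c4ccc(Cl)cc4Cl)nc3-c3ccccc3)cc2N1` differs from compound 1 by 2,4-dichlorophenyl in place of 4-methoxyphenyl on an aromatic carbon. Going by the values given here, no measured pair shows this change, so its size is unknown here; a step from compound 1 to compound 3 of no more than the scatter is expected in this assay, if anything toward a stronger effect. Compound 3 is estimated at 88%, expected between 70% and 100%, a step of a number 8 percentage points lower from compound 1 to compound 3 (within the scatter).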

Compound 3, a percentage reported as activity, at one concentration (the size of the read-out at that concentration, not a potency): 97.8%
Estimate against measurement, compound 3: 9.8 percentage points below; the range from low to high includes it.
By their numbers in this assay, from the lowest: compounds 2, 1 and 3 (each within the scatter of the next).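

In this assay, 2,4-dichlorophenyl in place of 4-methoxyphenyl on the aromatic carbon between two ring nitrogen atoms gives a number 1.8 percentage points higher from compound 1 to compound 3 (within the scatter). At this position, then, the two aryl groups cannot be told apart at the one concentration tested, even though the methoxy oxygen is replaced by two chlorine atoms. Nothing available here accounts for this result.

Going by these compounds, whether an amine or a carboxylic acid on this aryl ring would shift the read-out stays open. So does whether a non-aromatic group at this position, such as a longer chain, would do so.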